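The source may hold more compounds than are shown below. What is called first, only, known or untested is meant among the compounds shown, and "the series" means these compounds.

Compound 1 `C/C1=C/[C@]23O[C@H]2[C@H](C)C=C3C(=O)[C@@](C)(O)C(=O)CC(C)(C)/C=C/C1=O`: 26000 nM
Compound 2 `CC1=C2CC(C)(C)/C=C/[C@H](O)/C(C)=C\C3=C[C@H](C)C[C@]3(O2)C1=O`: 26000 nM
Compound 3 `CC1=C2CC(C)(C)/C=C/[C@@H](O)/C(C)=C\C3=C[C@H](C)C[C@]3(O2)C1=O`: 26000 nM

In an ADME assay on HEK293 cells (Homo sapiens) for cytotoxicity, read by CellTiter-Glo, with a stated time of 72 h (on this read-out lower numbers stand for an effect already at smaller amounts and higher numbers for an effect only at larger amounts of compound), level with compound 1 and compound 3, compound 2 stands at 26000 nM. Compound 4 `CC1=C2CC(C)(C)/C=C/[C@H](OC(=S)n3ccnc3)/C(C)=C\C3=C[C@H](C)C[C@]3(O2)C1=O` carries a group of 7 heavy atoms (4 carbon, 2 nitrogen, 1 sulfur; one five-membered aromatic ring with 2 hetero atoms) in place of a hydrogen atom, on an oxygen on a saturated carbon. Among the measured compounds shown here, the one measured step that bears on this is no change at the digits printed from compound 2 to compound 3 (within the scatter), and it reflects (the fact that compounds 2 and 3 differ only in the configuration as drawn). For the measured compounds named here, that step tests configuration only, and no measured step adds a group at this oxygen, so the guide is weak. A modest move towards effect at smaller amounts is expected, amounting to a 1.7-fold lower number from compound 2 to compound 4 (0.24 log units; within the scatter), with no change beyond the scatter still possible. For compound 4 the estimated value in this assay is 15000 nM, with an expected range from 4000 nM to 30000 nM.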

Compound 4, half-maximal effective concentration: 26000 nM
Estimate against measurement, compound 4: 1.7-fold (0.24 log units) below; low and high end bracket the measured number.
By their numbers in this assay, from the lowest: compounds 1, 2, 3 and 4 (each within the scatter of the next).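

With the hydrogen on this oxygen replaced by a group of 7 heavy atoms, this assay shows no change at the digits printed from compound 2 to compound 4 (within the scatter). The earlier compounds shown here tested only the configuration at this carbon, whereas compound 4 shows that a substituent containing one five-membered aromatic ring with 2 hetero atoms also leaves the reading unmoved. Nothing at hand gives a cause for this result.

On these data alone, whether a methyl ether, an acetyl ester or a chain ending in an amine on this oxygen would read the same stays open. So does the effect of the same group on the configuration of compound 3.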